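Swapping 1-methylpyrrolidin-2-yl for pyridin-2-yl in compound 3

A few compounds are considered here, and "the series" means these few. Any claim that something is new, unique, unknown or untested is made for them only; others in the source may bear on it.

Of the compounds shown here, three have been measured in a functional assay on A2780 cells (Homo sapiens) for antiproliferative activity, read by CellTiter-Glo, with a stated time of 4 days (on this read-out lower numbers stand for stronger inhibition and higher numbers for weaker inhibition), so far.

- Compound 1 `O=C(CCc1cccnc1)Nc1ccc(CN2C(=O)c3ccccc3C2=O)cc1` gives > 10000 nM as a limit of the assay, not a number
- Compound 2 `CCC(=O)NCc1ccc(NC(=O)[C@H]2C[C@@H]2c2cccnc2)cc1` gives 405 nM as its half-maximal inhibitory concentration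
- Compound 3 `C[C@H](NC(=O)[C@@H]1CCCN1C)c1ccc(NC(=O)[C@H]2C[C@@H]2c2cccnc2)cc1` gives 1 nM as its half-maximal inhibitory concentration

Among the two exact numbers, compound 3 at 1 nM has the lower one. The nearest, compound 2 at 405 nM on the same read-out, lies well beyond the scatter and on the side of weaker inhibition.

The next compound is compound 4 `C[C@H](NC(=O)c1ccccn1)c1ccc(NC(=O)[C@H]2C[C@@H]2c2cccnc2)cc1` and it departs from compound 3 in one place. It carries pyridin-2-yl in place of 1-methylpyrrolidin-2-yl on a carbonyl carbon and the rest of the structure stays the same.

Among the measured compounds shown here, no measured pair of compounds shows this exchange on its own, so the expectation is a loose one. It starts from compound 3 at 1 nM as a very low number, from which a move towards weaker inhibition is more likely than a further gain. The estimated change is a 5.0-fold higher number from compound 3 to compound 4 (0.70 log units; beyond the scatter) in this assay and it is expected to stay small beside the gap that separates the two exact numbers. For compound 4 the estimate is 5 nM in the range 1 nM to 30 nM as an expected value.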

Compound 4, half-maximal inhibitory concentration: 14 nM
The estimate for compound 4 lay 2.8-fold (0.45 log units) below the measured number; measured number inside the range.
By their numbers in this assay, from the lowest: compound 3; then compound 4; then compound 2. At a limit, above all of these: compound 1.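

In this assay, among the compounds shown here, the exchange of 1-methylpyrrolidin-2-yl for pyridin-2-yl on a carbonyl carbon gives a 14-fold higher number from compound 3 to compound 4 (1.15 log units; beyond the scatter) and is the first one-place step, showing that the outcome at this position depends on which group it carries. The two groups have matching counts of heavy atoms, hydrogen-bond donors and hydrogen-bond acceptors, and neither carries a net charge, so these counts alone do not settle the result. The step does show that the group in compound 3 is not indispensable for a low number, as compound 4 with its six-membered aromatic ring gives 14 nM in the same assay.

Nothing measured here accounts for the size of this step, and the step itself cannot separate the change in ring size, the change to an aromatic ring and the loss of the defined stereocentre:. On these data alone, it remains open how an open-chain amine such as dimethylaminomethyl, a pyrrolidin-2-yl ring without the methyl group or a plain phenyl ring would compare on the same carbonyl carbon.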